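This account rests on a few compounds, and the source may have more. Where it says the series, first, only, none or still open, it means among the compounds named here.

Measured so far:
compound 1 `COc1ccc(Nc2nc(Oc3cccc(NC(=O)/C=C/C(C)C)c3)c3sccc3n2)cc1`, > 50000 nM
compound 2 `C/C=C/C(=O)Nc1cccc(Oc2nc(Nc3cccc(OC)c3)nc3ccsc23)c1`, 14600 nM

Among the compounds with values here, in a functional assay on MCF7 cells (Homo sapiens) for inhibition, read by MTT assay, with a stated time of 72 h (a lower number here means a stronger inhibitor, a higher number a weaker inhibitor), compound 2 gives 14600 nM, the only plain number among the two values shown. Compound 1 sits at the limit of > 50000 nM in this assay, at which 1 of the 2 values shown sits, which is a limit of this assay and not a number. The unmeasured compound 3 `CCC/C=C/C(=O)Nc1cccc(Oc2nc(Nc3cccc(OC)c3)nc3ccsc23)c1` differs from compound 2 by ethyl in place of hydrogen on a saturated chain carbon bound to a double-bonded chain carbon. Within the data shown here, no step between measured compounds is known, so the expectation rests on compound 2 alone, and the change is expected to stay within the usual scatter, in either direction. Compound 3 is expected at 15000 nM, with a range from 5000 nM to 45000 nM. The expected step is a 1.0-fold higher number from compound 2 to compound 3 (0.01 log units; within the scatter).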

Compound 3, half-maximal inhibitory concentration: 5020 nM
The estimate for compound 3 lay 3.0-fold (0.48 log units) above the measured number; the measured number falls inside the stated range.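

In this assay, ethyl in place of hydrogen on a saturated chain carbon bound to a double-bonded chain carbon gives a 2.9-fold lower number from compound 2 to compound 3 (0.46 log units; beyond the scatter). Within the data shown here, this is the first step that can be read at this position, and it shows that extending the chain here changes the number beyond the scatter, which the earlier compounds, with no step between them, could not show. Nothing measured here gives a cause for this step.

On these data alone, whether a longer chain at this carbon would lower the number further remains open. So does the effect of an amine or a carboxylic acid at the end of the chain.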